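A butoxy group on the aromatic ring of compound 3

The source may report more compounds than this note shows. Statements on the series, on what has been measured and on what is new or still open speak of the compounds shown alone.

Compound 1, `COc1cccc(/C=C2\CCCN=C2c2cccnc2)c1`, gives 1180 nM in an assay on membranes from brain for displacement of a labelled ligand from Neuronal acetylcholine receptor; alpha4/beta2 (Rattus norvegicus), with a stated time of 3 h; a higher number here means a weaker inhibitor, a lower number a stronger inhibitor.
Compound 2, `CC(C)(C)C(=O)Oc1ccccc1/C=C1\CCCN=C1c1cccnc1`, gives 1440 nM in this assay.
Compound 3, `C(=C1\CCCN=C1c1cccnc1)\c1ccccc1`, gives 850 nM in this assay.

Compound 3 has the lowest of the three numbers, but its gaps to compound 1 and to compound 2 are both within the scatter, so no order among them can be claimed. Compound 4, `CCCCOc1ccc(/C=C2\CCCN=C2c2cccnc2)cc1`, differs from compound 3 by butoxy in place of hydrogen on an aromatic carbon. Going by the values given here, two measured steps bear on this change: a 1.4-fold lower number from compound 1 to compound 3 (0.14 log units; within the scatter) and a 1.7-fold lower number from compound 2 to compound 3 (0.23 log units; within the scatter), each the removal of an oxygen-linked group from the same aromatic ring, and each within the scatter. Adding an oxygen-linked group to that ring is therefore expected to move this assay only slightly, if at all, with a step of a 1.4-fold higher number from compound 3 to compound 4 (0.15 log units; within the scatter) expected. Compound 4 is estimated at 1200 nM, with a range from 450 nM to 3500 nM.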

Compound 4, inhibition constant: 1960 nM
Compound 4: the middle estimate sits 1.6-fold (0.21 log units) below what was measured; measured number inside the range.
By their numbers in this assay, from the lowest: compounds 3, 1, 2 and 4 (each within the scatter of the next, the first and the last beyond it).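

Butoxy in place of hydrogen, on an aromatic carbon para to a large group, gives a 2.3-fold higher number from compound 3 to compound 4 (0.36 log units; beyond the scatter) in this assay, the first single change in this set to lie beyond the scatter. Unlike the steps involving methoxy and ((tert-butyl)carbonyl)oxy, this one shows that an oxygen-linked group on the aromatic ring can raise the number measurably, though only modestly. No evidence at hand bears on the reason for this step.

On these data alone, it remains open whether a longer chain such as hexyloxy at this place would raise the number further, and whether an amine or a carboxylic acid there would move it at all.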